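A few compounds are considered here, and "the series" means these few. Any claim that something is new, unique, unknown or untested is made for them only; others in the source may bear on it.

Series in an ADME assay on L02 cells (Homo sapiens) for cytotoxicity, read by MTT assay, with a stated time of 24 h (a lower number here means a stronger inhibitor, a higher number a weaker inhibitor), with values in brackets

Compound 1 `COc1cc(/C=C2\CN(S(=O)(=O)c3ccc(F)cc3)C/C(=C\c3cc(OC)c(OC)c(OC)c3)C2=O)cc(OC)c1OC` (12100 nM)
Compound 2 `COc1cc(/C=C2\CN(S(=O)(=O)c3ccc(NC(C)=O)cc3)C/C(=C\c3cc(OC)c(OC)c(OC)c3)C2=O)cc(OC)c1OC` (13600 nM)
Compound 3 `N#Cc1ccc(/C=C2\CN(S(=O)(=O)c3ccc(F)cc3)C/C(=C\c3ccccc3F)C2=O)cc1` (21900 nM)

Compound 1 stands within the scatter of both compound 2 and compound 3. Compound 4 `COc1cc(/C=C2\CN(S(=O)(=O)c3ccc(F)cc3)C/C(=C\c3cc(OC)c(OC)c(OC)c3)C2=O)cc(OC)c1` turns 3,4,5-trimethoxyphenyl into 3,5-dimethoxyphenyl, with hydrogen in place of methoxy on an aromatic carbon on an aromatic carbon. For the measured compounds named here, the one measured step, a 1.1-fold higher number from compound 1 to compound 2 (0.05 log units; within the scatter) for acetamido in place of fluoro, is a different change and stays within the scatter. Going by the values given here, no measured step removes a single methoxy. Compound 3 differs in several places, carries no methoxy group, and its value (21900 nM) is still within the scatter of compound 1. The step expected in this assay is therefore small, a 1.2-fold higher number from compound 1 to compound 4 (0.06 log units; within the scatter) and no larger than the scatter. For compound 4 the estimated value is 14000 nM (expected range 7000 nM to 28000 nM).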

Compound 4, half-maximal inhibitory concentration: 12300 nM
Compound 4: middle estimate off by 1.1-fold (0.06 log units), on the high side; the range from low to high includes it.
By their numbers in this assay, from the lowest: compounds 1, 4, 2 and 3 (each within the scatter of the next).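

In this assay, for the compounds shown here, the step for hydrogen in place of methoxy, para to a large group and ortho to two methoxy groups, is a 1.0-fold higher number from compound 1 to compound 4 (0.01 log units; within the scatter) and gives the first reading at this position: this methoxy can go without a step beyond the scatter. Compound 4 keeps its other 3,4,5-trimethoxyphenyl group, so the reading covers one of the two aryl groups only. No evidence accompanying the series bears on this result.

As far as these compounds go, whether an amine, a hydroxy group or a longer alkoxy chain at this carbon would also stay within the scatter remains open. So does the outcome of the same change on the other 3,4,5-trimethoxyphenyl group.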